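A few compounds are considered here, and "the series" means these few. Any claim that something is new, unique, unknown or untested is made for them only; others in the source may bear on it.

Measured compounds in the series:

compound 1, `C/C(=N\O)c1cccc(Sc2cc(F)cc(C3CCOCC3)c2)c1`, 2910 nM
compound 2, `C/C(=N\OCCSc1nnnn1C)c1ccc(Sc2cc(F)cc(C3CCOCC3)c2)cc1`, 120 nM
compound 3, `COC1(c2csc(Sc3ccc4c(c3)OCC/C4=N\O)c2)CCOCC1`, 40 nM

All three values come from a functional assay (blood) for inhibition, with Homo sapiens as the target; on this read-out lower numbers stand for stronger inhibition and higher numbers for weaker inhibition. On these three numbers compound 2 stands second highest: compound 3 sits nearest, with a lower number, and compound 1 furthest, with a higher number; both gaps lie beyond the usual scatter. Going by the values given here, compound 1 carries a free oxime and compound 3 a different core, so neither pair with compound 2 differs in a single place and no step between them is given; their values are noted only as they stand.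

The next compound, compound 4, is `C/C(=N\OC(=O)C(C)(C)C)c1ccc(Sc2cc(F)cc(C3CCOCC3)c2)cc1`. It is not yet measured in this assay. It differs from compound 2 in one place:

(tert-butyl)carbonyl in place of 2-((1-methyl-1H-tetrazol-5-yl)sulfanyl)ethyl on an oxygen

Among the compounds with values here, for the step from compound 2 to compound 4 no measured analogue exists. The group that enters is smaller than the group that leaves and lacks the ring; the expectation is a moderate loss of potency, a step beyond the scatter but well short of the gap to compound 1. Compound 4 is estimated at 300 nM, in a range of 80 nM to 1500 nM, which means an expected step of a 2.5-fold higher number from compound 2 to compound 4 (0.40 log units; beyond the scatter).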

Compound 4, half-maximal inhibitory concentration: 40 nM
Estimate against measurement, compound 4: 7.5-fold (0.88 log units) above; the measured number lies below the stated range.
By their numbers in this assay, from the lowest: compounds 3 and 4 (each within the scatter of the next); then compound 2; then compound 1.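

In this assay, the oxygen whose other neighbour is the double-bonded nitrogen tolerates a marked change of substituent: (tert-butyl)carbonyl in place of 2-((1-methyl-1H-tetrazol-5-yl)sulfanyl)ethyl gives a 3.0-fold lower number from compound 2 to compound 4 (0.48 log units; beyond the scatter). Compound 4 reaches 40 nM with no ring in the group on this oxygen, so the five-membered aromatic ring with 4 hetero atoms and the sulfur of the leaving group are not needed for inhibition at this level. Nothing on hand bears on the reason for this step.

Going by these compounds, it remains open which part of the (tert-butyl)carbonyl group goes with the lower number: an acetyl group on the same oxygen would keep the carbonyl without the tert-butyl, and a 2,2-dimethylpropyl chain would keep the tert-butyl without the carbonyl. Going by these compounds alone, also open is the reading of a free oxime on the shared core of compound 2 and compound 4, as compound 1 differs from both in more than one place and its 2910 nM gives no step.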